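Phenyl for methyl on the acylguanidine side chain

The source may hold more compounds than are shown below. What is called first, only, known or untested is meant among the compounds shown, and "the series" means these compounds.

Compound 2 `CC(CC(=O)/N=C(\N)NCCCn1ccnc1)c1ccccc1` sits at the floor of a functional assay on Sf9 cells for antagonist activity at histamine H2 receptor (Homo sapiens), with stated times of 2 min and 20 min; a lower number here means a less potent compound, a higher number a more potent compound, by a factor of ten per unit of this negative logarithm. In this assay compound 2 gives only < 5, which is a limit of the assay and not a number (the limit of < 5 in this assay, at which 1 of the 2 values shown sits). Compound 3 `N/C(=N\C(=O)CC(c1ccccc1)c1ccccc1)NCCCn1ccnc1` differs from compound 2 by phenyl in place of methyl on a saturated chain carbon bound to an aromatic carbon and a saturated chain carbon. Compound 1 `N/C(=N\C(=O)CC(c1ccccc1)c1ccccc1)NCCCc1ccccn1` carries the same phenyl in place of methyl and gives 5.68 in this assay, which supports a gain. The expected step of a number at least 0.50 log units higher from compound 2 to compound 3 (beyond the scatter) is upward and beyond the scatter, its size uncertain since it starts from a limit. Compound 3 is estimated at 5.5, within 5 to 6.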

Compound 3, negative logarithm of the antagonist equilibrium constant: 5.82
Compound 3: middle estimate off by 0.32 log units, on the low side; the measured number falls inside the stated range.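

In this assay the phenyl in place of methyl on this saturated chain carbon now has its own direct pair, with a step of a number at least 0.82 log units higher from compound 2 to compound 3 (beyond the scatter). Going by these compounds, compound 2 is a limit of the assay and not a number, and the true size of that step stays unknown: the limit of < 5 in this assay, at which 1 of the 3 values shown sits. With phenyl held on that carbon, 1H-imidazol-1-yl in place of pyridin-2-yl gives a number 0.14 log units higher from compound 1 to compound 3 (within the scatter), and the two compounds cannot be told apart. Open: whether benzyl or cyclohexyl in place of phenyl keeps this potency, and whether a longer chain to the 1H-imidazol-1-yl group does.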